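A few compounds are considered here, and "the series" means these few. Any claim that something is new, unique, unknown or untested is made for them only; others in the source may bear on it.

In a functional assay on DU-145 cells (Homo sapiens) for cytotoxicity, read by MTT assay, with a stated time of 48 h (a lower number here means a stronger inhibitor, a higher number a weaker inhibitor), compound 3, `Cc1ccc(S(=O)(=O)/N=C(/CCNC2=CC(=O)c3ccccc3C2=O)NCc2ccccc2)cc1`, gives 9120 nM. Among the measured compounds shown here, that is the lowest of the three numbers so far: compound 1, `Cc1ccc(S(=O)(=O)/N=C(/CCNC2=CC(=O)c3ccccc3C2=O)Nc2ccc(Cl)cc2Cl)cc1`, gives 18600 nM, and compound 2, `Cc1ccc(S(=O)(=O)/N=C(/CCNC2=CC(=O)c3ccccc3C2=O)NC(C)C)cc1`, gives 28500 nM. The next compound is compound 4, `Cc1ccc(S(=O)(=O)/N=C(/CCNC2=CC(=O)c3ccccc3C2=O)NC2CCCCC2)cc1`, which differs from compound 3 by cyclohexyl in place of benzyl on an amine nitrogen. Two of the measured steps bear on this change. They alter the same amine nitrogen substituent. The step from compound 1 to compound 3 was a 2.0-fold lower number from compound 1 to compound 3 (0.31 log units; beyond the scatter), and the step from compound 2 to compound 3 was a 3.1-fold lower number from compound 2 to compound 3 (0.49 log units; beyond the scatter); both show benzyl on that nitrogen giving a lower number than either alternative tried. The step from compound 2 to compound 3 is the closer guide, since it trades a non-aromatic alkyl group for benzyl, and compound 4 moves back to a non-aromatic ring. A modest rise in this assay is therefore expected, a 1.8-fold higher number from compound 3 to compound 4 (0.24 log units; within the scatter). Compound 4 is estimated at 16000 nM, with a likely range from 7000 nM to 36000 nM.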

Compound 4, half-maximal inhibitory concentration: 16600 nM
Compound 4: the middle estimate sits 1.0-fold (0.02 log units) below what was measured; low and high end bracket the measured number.
By their numbers in this assay, from the lowest: compounds 3, 4, 1 and 2 (each within the scatter of the next, the first and the last beyond it).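

In this assay, the change from benzyl to cyclohexyl on this amine nitrogen is a 1.8-fold higher number from compound 3 to compound 4 (0.26 log units; within the scatter), so the non-aromatic ring cannot be told apart here from the aromatic ring of benzyl. The comparisons with the other two groups read the same way: a 1.7-fold lower number from compound 2 to compound 4 (0.23 log units; within the scatter) against isopropyl and a 1.1-fold lower number from compound 1 to compound 4 (0.05 log units; within the scatter) against 2,4-dichlorophenyl. Compound 4 therefore lies within the scatter of all three earlier compounds, even though compound 2 and compound 3 lie beyond the scatter of each other, so the gap between benzyl and isopropyl does not mark a clear divide between ring types.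

Nothing available explains these steps. Open too, from the compounds shown here alone, is whether a longer chain such as phenethyl, or a hydroxyl or amine on the ring, would move the number at this nitrogen beyond the scatter.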